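Side-chain variation at the amide-bound carbon of the series

A few compounds are considered here, and "the series" means these few. Any claim that something is new, unique, unknown or untested is made for them only; others in the source may bear on it.

Measured compounds:
compound 1 `COc1ccc(OCC(=O)N2CCN(c3ccc(C(F)(F)F)cc3[C@@H](N)CC(C)C)CC2)cc1`: 3800 nM
compound 2 `CC(C)C[C@H](N)c1cc(C(F)(F)F)ccc1N1CCN(C(=O)CCC2CCCCC2)CC1`: 5700 nM
compound 3 `CC(C)C[C@H](N)c1cc(C(F)(F)F)ccc1N1CCN(C(=O)CSc2ccc(Cl)cc2Cl)CC1`: 1500 nM

In an assay on HEK293 cells for displacement of a labelled ligand from Melanocortin receptor 4 (Homo sapiens) (a higher number here means a weaker inhibitor, a lower number a stronger inhibitor), compound 3 holds the lowest number of the three, and both of its steps are beyond the scatter: a 2.5-fold lower number from compound 1 to compound 3 (0.40 log units; beyond the scatter) and a 3.8-fold lower number from compound 2 to compound 3 (0.58 log units; beyond the scatter). The two groups it is compared with are themselves close together, since a 1.5-fold higher number from compound 1 to compound 2 (0.18 log units; within the scatter).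

Compound 4 `CC(C)C[C@H](N)c1cc(C(F)(F)F)ccc1N1CCN(C(=O)COc2cccc(Cl)c2Cl)CC1` is the next member. (2,3-dichlorophenoxy in place of (2,4-dichlorophenyl)sulfanyl on a saturated chain carbon bound to a carbonyl carbon).

Among the measured compounds shown here, only one measured step bears on the change, the one from an aryl ether to an aryl thioether at the same place: a 2.5-fold lower number from compound 1 to compound 3 (0.40 log units; beyond the scatter), a modest gain for the thioether, though the aryl substitution pattern also differed there. For the measured compounds named here, no measured pair isolates the shift of a chlorine from one ring position to another, nor the ether-to-thioether swap on its own. Taking the phenoxy compound 1 with 3800 nM as the nearer reference, a step back toward higher numbers is expected for compound 4, of modest size: a 1.7-fold higher number from compound 3 to compound 4 (0.22 log units; within the scatter). Compound 4 is therefore estimated at 2500 nM, with a range from 900 nM to 7000 nM.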

Compound 4, inhibition constant: 2500 nM
Beside the measured number, compound 4's estimate shows no gap at the digits printed; measured number inside the range.
By their numbers in this assay, from the lowest: compounds 3, 4, 1 and 2 (each within the scatter of the next, the first and the last beyond it).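

In this assay, the 2,3-dichlorophenoxy group cannot be told apart from either aryl-containing neighbour at this position: a 1.7-fold higher number from compound 3 to compound 4 (0.22 log units; within the scatter) and a 1.5-fold lower number from compound 1 to compound 4 (0.18 log units; within the scatter). It does stand clear of the cyclohexylmethyl group, a 2.3-fold lower number from compound 2 to compound 4 (0.36 log units; beyond the scatter), whereas the 4-methoxyphenoxy group did not, a 1.5-fold higher number from compound 1 to compound 2 (0.18 log units; within the scatter), so an oxygen-linked aryl group can now separate from compound 2, and the gain seen with the (2,4-dichlorophenyl)sulfanyl group is not confined to a sulfur link. No measurement at hand accounts for any of these steps.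

The step from compound 3 to compound 4 changes both the linking atom and the chlorine pattern, so a 2,3-dichlorophenylsulfanyl or a 2,4-dichlorophenoxy group would be needed to read the two changes apart. Also open, on these data alone, is how a carboxylic acid, a primary amine or a longer chain carrying the dichlorophenyl ring would read on the saturated chain carbon bound to the carbonyl carbon.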